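From Compound 1 to Compound 4: Dropping a Carbamoyl Unit

The compounds below may be only part of what the source reports. "The series", "measured", "known", "first", "only" and "open" are said of these compounds alone.

Going by the values given here, in a functional assay on CCRF-CEM cells (Homo sapiens) for inhibition, read by MTT assay, with a stated time of 72 h (on this read-out lower numbers stand for stronger inhibition and higher numbers for weaker inhibition), compound 1 (`COc1cc(NC(C)CCCNC(=O)NNC(=O)Nc2ccc(Cl)cc2)c2ncccc2c1`) gives 108000 nM, the highest number of the three measured so far. Compound 2 (`COc1cc(NC(C)CCCNC(=O)NNC(=O)Nc2ccc(C(F)(F)F)cc2)c2ncccc2c1`) gives 18000 nM, and compound 3 (`COc1cc(NC(C)CCCNC(=O)Nc2cc(C(F)(F)F)cc(C(F)(F)F)c2)c2ncccc2c1`) gives 4100 nM. Compound 4 (`COc1cc(NC(C)CCCNC(=O)Nc2ccc(Cl)cc2)c2ncccc2c1`) has not yet been measured. It differs from compound 1 as follows: 4-chlorophenyl in place of ((4-chlorophenyl)carbamoyl)amino on an amide-type nitrogen. The swap sits on an amide-type nitrogen.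

Among the compounds with values here, no measured step isolates this change. Within the data shown here, the only measured step, a 6.0-fold lower number from compound 1 to compound 2 (0.78 log units; beyond the scatter), puts trifluoromethyl in place of chloro, so it bears on the question only indirectly: a change on the aromatic ring alone moved the number beyond the scatter. The closest comparison is compound 3, which also has its aromatic ring directly on the amide-type nitrogen and gives 4100 nM. However, that ring carries trifluoromethyl groups, whereas compound 4 keeps chloro, so a number as low as that of compound 3 is not assumed. A clear drop in this assay is still expected, estimated as a 7.2-fold lower number from compound 1 to compound 4 (0.86 log units; beyond the scatter). The estimate for compound 4 is 15000 nM, with an expected range from 4000 nM to 60000 nM.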

Compound 4, half-maximal inhibitory concentration: 24000 nM
Estimate against measurement, compound 4: 1.6-fold (0.20 log units) below, and the stated range covers the measured number.
By their numbers in this assay, from the lowest: compound 3; then compounds 2 and 4 (each within the scatter of the next); then compound 1.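

Putting 4-chlorophenyl in place of ((4-chlorophenyl)carbamoyl)amino on the amide-type nitrogen gives, in this assay, a 4.5-fold lower number from compound 1 to compound 4 (0.65 log units; beyond the scatter), the first step measured at this position. The earlier step altered only a substituent on the aromatic ring, whereas here the chloro on that ring stays and the carbamoyl unit linking it goes, so this change alone moves the number beyond the scatter. Nothing at hand explains this drop.

Still open is whether the same change would give a step of similar size with a trifluoromethyl on the ring, as no pair shown isolates it there. Also open, as far as these compounds go, is how the number would respond to a benzyl group on the amide-type nitrogen, or to a carboxylic acid on the aromatic ring.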